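The source may hold more compounds than are shown below. What is called first, only, known or untested is meant among the compounds shown, and "the series" means these compounds.

Compound 1 `COc1ccc(NC(=O)C(=O)c2cn(C(C)C)c3ccccc23)cc1` gives 181 nM in a functional assay on FaDu cells (Homo sapiens) for cytotoxicity, read by MTT assay, with a stated time of 72 h; on this read-out lower numbers stand for higher toxicity in this test and higher numbers for lower toxicity in this test. Compound 2 `COc1ccc(NC(=O)C(=O)c2cn(C(C)C)c3ccccc23)cn1` gives 85 nM in this assay; the step of a 2.1-fold lower number from compound 1 to compound 2 (0.33 log units; beyond the scatter) accompanies 6-methoxypyridin-3-yl in place of 4-methoxyphenyl on an amide-type nitrogen. Compound 3 `COc1ccc(NC(=O)C(=O)c2cn(C(C)C)c3ccc(Cl)cc23)cn1` reaches only a limit of this assay, (the limit of > 10000 nM in this assay, at which 1 of the 3 values shown sits), and is recorded as > 10000 nM. The step of an at least 110-fold higher number from compound 2 to compound 3 (2.07 log units; beyond the scatter) accompanies chloro in place of hydrogen on an aromatic carbon. Among the numbers given, compound 2 stands lowest of the two, with compound 1 the nearest; the third value is a limit rather than a number.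

Compound 4 `COc1ccc(NC(=O)C(=O)c2cn(CC3CCCO3)c3ccccc23)cn1` differs from compound 2 by (oxolan-2-yl)methyl in place of isopropyl on an aromatic nitrogen. Among the measured compounds shown here, no measured step touches the aromatic nitrogen of the five-membered ring of the shared core: the step from compound 1 to compound 2 alters the amide-type nitrogen and was modest, the step from compound 2 to compound 3 alters an aromatic carbon and was large. The change at the aromatic nitrogen is therefore read without direct precedent, and the expected step is a 2.9-fold higher number from compound 2 to compound 4 (0.47 log units; beyond the scatter) in this assay, carrying a wide range. Compound 4 is estimated at 250 nM, between 60 nM and 2000 nM in this assay.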

Compound 4, concentration lethal to 50% of the cells in the FaDu assay: 31 nM
The estimate for compound 4 lay 8.1-fold (0.91 log units) above the measured number; measured number below the stated range.
By their numbers in the FaDu assay, from the lowest: compound 4; then compound 2; then compound 1. At a limit, above all of these: compound 3.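

Among the compounds shown here, the aromatic nitrogen of the shared core, untouched by the earlier steps, now has a step of its own: in the FaDu assay, (oxolan-2-yl)methyl in place of isopropyl gives a 2.7-fold lower number from compound 2 to compound 4 (0.44 log units; beyond the scatter), and compound 4 stands at 31 nM. At this position, a group with more heavy atoms, a non-aromatic ring and a hydrogen-bond acceptor therefore goes with a lower number than isopropyl. In a physicochemical assay for solubility, in phosphate buffer, at pH 7.4 (a lower number here means a less soluble compound, a higher number a more soluble compound), compound 2 gives 20000 nM and compound 4 gives 10000 nM; the same change gives a 2.0-fold lower number from compound 2 to compound 4 (0.30 log units; within the scatter), so the two compounds cannot be told apart on that read-out.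

Nothing shown accounts for the step in cells. Still open, as far as these compounds go, is whether the ring or its oxygen goes with the step, a question that cyclopentylmethyl or a longer chain such as 2-methoxyethyl on the same nitrogen would address.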